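Amine substituent changes on the shared core

The compounds below may be only part of what the source reports. "The series", "measured", "known", "first", "only" and "open" are said of these compounds alone.

Measured compounds:
compound 1 `CCCc1ccc(NC2=CC(=O)c3nc4n(c3C2=O)[C@H]2OC[C@@H](O)[C@H]2OC4)cc1`: 1560 nM
compound 2 `O=C1C=C(N2CCC2)C(=O)c2c1nc1n2[C@H]2OC[C@@H](O)[C@H]2OC1`: the value > 16000 nM is a limit of the assay, not a number
compound 3 `O=C1C=C(Nc2ccccc2F)C(=O)c2c1nc1n2[C@H]2OC[C@@H](O)[C@H]2OC1`: 2080 nM

In a functional assay on MGC-803 cells (Homo sapiens) for inhibition, read by sulforhodamine B assay (a lower number here means a stronger inhibitor, a higher number a weaker inhibitor), compound 3 gives 2080 nM, the highest of the two numbers shown. Compound 1 gives 1560 nM in this assay, and the step of a 1.3-fold higher number from compound 1 to compound 3 (0.12 log units; within the scatter) is within the scatter, so the two aryl groups on the amine nitrogen read alike. For compound 2 only a limit is known, (the limit of > 16000 nM in this assay, at which 1 of the 3 values shown sits). The step of an at least 7.6-fold lower number from compound 2 to compound 3 (0.88 log units; beyond the scatter) is beyond the scatter.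

Compound 4 `O=C1C=C(NC2CCCCC2)C(=O)c2c1nc1n2[C@H]2OC[C@@H](O)[C@H]2OC1` differs from compound 3 by cyclohexyl in place of 2-fluorophenyl on an amine nitrogen. For the measured compounds named here, no measured step covers a non-aromatic ring on this amine nitrogen while the amine hydrogen is kept; the step from compound 2 to compound 3 is the nearest guide and points toward a weaker result for a non-aromatic group, while the step from compound 1 to compound 3 shows the aromatic ring itself could be varied freely. A modest rise in number is therefore expected, the step being estimated as a 1.7-fold higher number from compound 3 to compound 4 (0.23 log units; within the scatter). Compound 4 is estimated at 3500 nM, within a range from 1200 nM to 12000 nM.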

Compound 4, half-maximal inhibitory concentration: > 8000 nM
Compound 4: no number, only a limit; the forecaster's own chance of this, stated with the estimate: 15%; at least 2.2-fold (0.35 log units) between middle value and limit.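

Compound 4 gives no number, only a limit: the limit of > 8000 nM in this assay, at which 1 of the 4 values shown sits.

Even so, this assay shows an at least 3.8-fold higher number from compound 3 to compound 4 (0.58 log units; beyond the scatter) and an at least 5.1-fold higher number from compound 1 to compound 4 (0.70 log units; beyond the scatter), so on this amine nitrogen cyclohexyl separates from 2-fluorophenyl and 4-propylphenyl, whereas the two aryl groups read alike. The step between compound 2 and compound 4 cannot be read, as both carry limits.

The compounds shown do not settle whether the aromatic ring itself is needed on this amine nitrogen, or whether other groups could also stay with the aryl compounds. A benzylamino group, a straight butyl chain on the amine nitrogen, or a phenyl ring carrying a carboxylic acid would test this on the shared core.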